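Methyl for fluoro on the core of compound 1

The compounds below may be only part of what the source reports. "The series", "measured", "known", "first", "only" and "open" are said of these compounds alone.

A small series of three measured compounds shares a fused core and was tested in a functional assay on A549 cells (Homo sapiens) for inhibition, read by sulforhodamine B assay, with a stated time of 48 h; a lower number here means a stronger inhibitor, a higher number a weaker inhibitor. Compound 1 `O=C1[C@H]2[C@H](ON(c3ccccc3)[C@@H]2c2coc3ccc(F)cc3c2=O)C(=O)N1c1ccccc1` gives 13500 nM in this assay. Compound 3 `O=c1c([C@@H]2C[C@H](c3ccncc3)ON2c2ccccc2)coc2ccccc12` gives 19300 nM and compound 2 `CCO[C@H]1C[C@@H](c2coc3cc(Cl)c(Cl)cc3c2=O)N(c2ccccc2)O1` gives 19800 nM. The differences between compound 1 and each of the other two fall within the scatter of repeated measurements, so the three cannot be ranked against one another; all three are weak inhibitors in this assay.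

Compound 4 `Cc1ccc2occ([C@@H]3[C@H]4C(=O)N(c5ccccc5)C(=O)[C@H]4ON3c3ccccc3)c(=O)c2c1` has not yet been measured. It differs from compound 1 in one place: methyl in place of fluoro on an aromatic carbon. The exchange keeps the heavy-atom count, adds no donor or acceptor and brings no charge. Within the data shown here, no measured pair in this set shows what such an exchange does to the number in this assay, so there is no directly comparable step to lean on. The expectation is therefore anchored on compound 1 at 13500 nM, with a step from compound 1 to compound 4 that is estimated to be small, a 1.0-fold lower number from compound 1 to compound 4 (0.02 log units; within the scatter), in no clear direction and not beyond the scatter. On that basis compound 4 is expected to give about 13000 nM in this assay, with a plausible range from 4500 nM to 40000 nM.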

Compound 4, half-maximal inhibitory concentration: > 60000 nM
Compound 4 was reported as a limit; the forecaster's own chance of this, stated with the estimate: 15%; middle value at least 4.6-fold (0.66 log units) away from the limit.
By their numbers in this assay, from the lowest: compounds 1, 3 and 2 (each within the scatter of the next). At a limit, above all of these: compound 4.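

Among these compounds, compound 4 supplies the first step in this set that changes one place only: in this assay, methyl in place of fluoro on an aromatic carbon gives an at least 4.4-fold higher number from compound 1 to compound 4 (0.64 log units; beyond the scatter). The value of compound 4 is a limit and not a number: the limit of > 60000 nM in this assay, at which 1 of the 4 values shown sits. This aromatic carbon of the shared core is therefore not indifferent to what it carries, since two groups of one heavy atom each, neither with a hydrogen-bond donor or acceptor or a net charge, are separated by more than the scatter, something the three earlier compounds, all within the scatter of one another, could not show.

The compounds shown leave open what a methoxy group, a nitrile or an amine would do at this carbon, and whether plain hydrogen there would sit with compound 1 or with compound 4. They also give no measured property of fluoro or methyl that would account for the step, and this single pair cannot say whether the same exchange would have a similar effect elsewhere on the core.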